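Quinazolinone-type series: extending the sulfur substituent of compound 3

A few compounds are considered here, and "the series" means these few. Any claim that something is new, unique, unknown or untested is made for them only; others in the source may bear on it.

Measured so far in a functional assay on HeLa cells (Homo sapiens) for antiproliferative activity, read by MTT assay, with a stated time of 48 h; a higher number here means a weaker inhibitor, a lower number a stronger inhibitor:
compound 1 `Cc1ccc(-c2nc3ccc(Cl)cc3c(=O)n2N)cc1` — 12.1 ug/mL
compound 2 `Cc1ccc(C(=O)Nc2ccc(Cl)cc2C(=S)NN)cc1` — 4.98 ug/mL
compound 3 `CSc1nc(-c2ccc(C)cc2)nc2ccc(Cl)cc12` — 14.7 ug/mL

Compound 3 gives the highest of the three numbers. Against compound 1 the gap lies within the scatter; against compound 2 it lies beyond it, with compound 2 giving the lower number.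

Compound 4 `Cc1ccc(-c2nc(SCC(=O)Nc3ccc(F)cc3)c3cc(Cl)ccc3n2)cc1` differs from compound 3 in one place: (4-fluorophenyl)carbamoyl in place of hydrogen on a saturated chain carbon bound to a sulfur. Within the data shown here, no pair of measured compounds shows this kind of change, so there is no step to lean on.

The expectation is a small move toward a lower number, a 1.7-fold lower number from compound 3 to compound 4 (0.24 log units; within the scatter), not clearly beyond the scatter. Compound 4 is estimated at 8.5 ug/mL, with a range from 3 ug/mL to 25 ug/mL.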

Compound 4, half-maximal inhibitory concentration: 10.5 ug/mL
Compound 4: the middle estimate sits 1.2-fold (0.09 log units) below what was measured, within the range that was stated.
By their numbers in this assay, from the lowest: compound 2; then compounds 4, 1 and 3 (each within the scatter of the next).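

On the saturated chain carbon bound to the sulfur, (4-fluorophenyl)carbamoyl in place of hydrogen adds 10 heavy atoms, and the read-out in this assay shows a 1.4-fold lower number from compound 3 to compound 4 (0.15 log units; within the scatter) as the step. Among these compounds, this position therefore accepts a large amide-bearing substituent without a shift beyond the scatter, which the earlier compounds could not show. No measurement at hand bears on the reason for this result.

As far as these compounds go, whether a carboxylic acid or a dimethylamino group on this same carbon would give a step beyond the scatter remains open. So does any contribution of the fluorine to the value of compound 4.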